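A Bromine for Three Methoxy Groups on the Terminal Ring

The compounds below may be only part of what the source reports. "The series", "measured", "known", "first", "only" and "open" are said of these compounds alone.

Three compounds share one core and differ only in the ring that hangs from the carbon with a double bond to nitrogen. Compound 1 `COc1ccc(/C=N/NC(=O)Nc2ccc(Oc3ccnc(-c4nncn4CCN(C)C)c3)c(F)c2)c(OC)c1` gives 1780 nM in a functional assay on HT-29 cells (Homo sapiens) for cytotoxicity, read by MTT assay, with a stated time of 72 h; a lower number here means a stronger inhibitor, a higher number a weaker inhibitor. Compound 2 `COc1ccc(/C=N/NC(=O)Nc2ccc(Oc3ccnc(-c4nncn4CCN(C)C)c3)c(F)c2)c(OC)c1OC` gives 3970 nM, and compound 3 `COc1cc(/C=N/NC(=O)Nc2ccc(Oc3ccnc(-c4nncn4CCN(C)C)c3)c(F)c2)cc(OC)c1OC` gives 3620 nM, so compound 3 stands second highest of the three, with compound 2 within the scatter of it and compound 1 giving a lower number a 2.0-fold higher number from compound 1 to compound 3 (0.31 log units; beyond the scatter). The other steps are a 2.2-fold higher number from compound 1 to compound 2 (0.35 log units; beyond the scatter) and a 1.1-fold lower number from compound 2 to compound 3 (0.04 log units; within the scatter).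

Compound 4 `CN(C)CCn1cnnc1-c1cc(Oc2ccc(NC(=O)N/N=C/c3cccc(Br)c3)cc2F)ccn1` carries the change (3-bromophenyl in place of 3,4,5-trimethoxyphenyl on a carbon with a double bond to nitrogen). Going by the values given here, no measured step swaps a methoxy-bearing ring for a halogen-bearing one, so none bears directly; the measured steps only show that reshuffling methoxy groups moves this assay modestly. The step from compound 3 to compound 4 is therefore expected to be small in either direction, a 1.2-fold lower number from compound 3 to compound 4 (0.08 log units; within the scatter). Compound 4 is estimated at 3000 nM, ranging from 900 nM to 10000 nM.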

Compound 4, half-maximal inhibitory concentration: 380 nM
Beside the measured number, compound 4's estimate is 7.9-fold (0.90 log units) above it; measured number below the stated range.
By their numbers in this assay, from the lowest: compound 4; then compound 1; then compounds 3 and 2 (each within the scatter of the next).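

In this assay the ring on the carbon with a double bond to nitrogen can move the number much further than swapping methoxy groups around did, with a 9.5-fold lower number from compound 3 to compound 4 (0.98 log units; beyond the scatter) and a 10-fold lower number from compound 2 to compound 4 (1.02 log units; beyond the scatter) and also a 4.7-fold lower number from compound 1 to compound 4 (0.67 log units; beyond the scatter). Compound 4 is the strongest of the four, and it has a single bromine on its ring and no methoxy groups at all, so methoxy groups are not needed at this position for activity in this assay. Nothing measured here explains the gain.

As far as these compounds go, the step removes the methoxy groups and adds the bromine together, so which of the two matters remains open. A plain phenyl ring, a 3-chlorophenyl ring or a 3-methoxyphenyl ring at the same place would help separate the two.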